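The source may report more compounds than this note shows. Statements on the series, on what has been measured and on what is new or still open speak of the compounds shown alone.

Compound 3 `COc1cc(OC)c(-c2coc3cc(OCc4ccccc4C)ccc3c2=O)cc1OC` shows the lowest number of the three measured compounds in a functional assay on U-251 cells (Homo sapiens) for antiproliferative activity, read by MTT assay, with a stated time of 24 h (on this read-out higher numbers stand for weaker inhibition and lower numbers for stronger inhibition), giving 2000 nM. Its nearest neighbour is compound 2 `COc1cc(OC)c(-c2coc3cc(OCc4ccccc4F)ccc3c2=O)cc1OC`, which gives 2890 nM; compound 1 `COc1ccc2c(=O)c(-c3cc(OC)c(OC)cc3OC)coc2c1` gives 9400 nM. Adding a substituted benzyl group to the shared core of compound 1 lowered the number, seen as a 3.3-fold lower number from compound 1 to compound 2 (0.51 log units; beyond the scatter) and a 4.7-fold lower number from compound 1 to compound 3 (0.67 log units; beyond the scatter), whereas swapping the group on that ring gave a 1.4-fold lower number from compound 2 to compound 3 (0.16 log units; within the scatter). Compound 4 `COc1cc(OC)c(-c2coc3cc(OCc4cccc(F)c4)ccc3c2=O)cc1OC` differs from compound 3 by 3-fluorophenyl in place of 2-methylphenyl on a saturated chain carbon bound to an oxygen on an aromatic ring. Within the data shown here, the one step that changes the substituent on this ring, the step from compound 2 to compound 3, stayed within the scatter, and no measured step moves its position; a small or no change is therefore expected, giving a 1.3-fold higher number from compound 3 to compound 4 (0.11 log units; within the scatter). Compound 4 is thus estimated at 2600 nM, between 1200 nM and 5600 nM.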

Compound 4, half-maximal inhibitory concentration: 3510 nM
Compound 4: the middle estimate sits 1.4-fold (0.13 log units) below what was measured, within the range that was stated.
By their numbers in this assay, from the lowest: compounds 3, 2 and 4 (each within the scatter of the next); then compound 1.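

In this assay, changing 2-fluorophenyl to 3-fluorophenyl (a 1.2-fold higher number from compound 2 to compound 4 (0.08 log units; within the scatter)) and 2-methylphenyl to 3-fluorophenyl (a 1.8-fold higher number from compound 3 to compound 4 (0.24 log units; within the scatter)) does not separate these compounds, so neither the group on this ring nor the place of its fluorine has yet shown a clear effect. The benzyl addition still holds with a third substituted ring (a 2.7-fold lower number from compound 1 to compound 4 (0.43 log units; beyond the scatter)). No measurement shown here offers an explanation for these results. On these data alone, whether an amine or a carboxylic acid on this ring would shift the number remains open, as does the effect of a longer chain in place of the benzyl group.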